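Ring swap on the core nitrogen: toward a smaller hydroxy carbocycle

A few compounds are considered here, and "the series" means these few. Any claim that something is new, unique, unknown or untested is made for them only; others in the source may bear on it.

Within the data shown here, compound 2 `COc1ccc(CCc2nc3cc(-c4c(C)noc4C)ccc3n2C2CCN(S(C)(=O)=O)CC2)cc1Cl` stands as the higher of the two numbers so far in an assay on isolated protein for inhibition of histone acetyltransferase p300 (Homo sapiens), read by AlphaLISA, with a stated time of 20 min; a higher number here means a weaker inhibitor, a lower number a stronger inhibitor: compound 2 gives 148 nM, while compound 1 `COc1ccc(CCc2nc3cc(-c4c(C)noc4C)ccc3n2[C@H]2CC[C@H](O)CC2)cc1Cl` gives 48 nM. Among the measured compounds shown here, the one step known is a 3.1-fold higher number from compound 1 to compound 2 (0.49 log units; beyond the scatter), where 1-(methylsulfonyl)piperidin-4-yl replaced 4-hydroxycyclohexyl on the aromatic nitrogen. Compound 3 `COc1ccc(CCc2nc3cc(-c4c(C)noc4C)ccc3n2[C@H]2C[C@H](O)C2)cc1Cl` carries the change (3-hydroxycyclobutyl in place of 1-(methylsulfonyl)piperidin-4-yl on an aromatic nitrogen). This undoes the sulfonylpiperidine of compound 2 and returns to a hydroxy carbocycle on the same nitrogen, though a four-membered one rather than the six-membered ring of compound 1, so the reverse of the measured step is the closest guide and is expected to apply only in part. Compound 3 is therefore expected to come in lower than compound 2 in this assay, by a 2.1-fold lower number from compound 2 to compound 3 (0.33 log units; beyond the scatter), with an estimated value of 70 nM in a range from 30 nM to 170 nM.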

Compound 3, half-maximal inhibitory concentration: 155 nM
The estimate for compound 3 lay 2.2-fold (0.35 log units) below the measured number, within the range that was stated.
By their numbers in this assay, from the lowest: compound 1; then compounds 2 and 3 (each within the scatter of the next).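

In this assay, a hydroxy carbocycle on this aromatic nitrogen does not by itself set the number: 3-hydroxycyclobutyl in place of 1-(methylsulfonyl)piperidin-4-yl gives a 1.0-fold higher number from compound 2 to compound 3 (0.02 log units; within the scatter), so these two groups cannot be told apart here. The two hydroxy carbocycles can be told apart, as 3-hydroxycyclobutyl in place of 4-hydroxycyclohexyl gives a 3.2-fold higher number from compound 1 to compound 3 (0.51 log units; beyond the scatter), and the four-membered ring does not retain the number of the six-membered one. No measurement at hand accounts for either step.

The compounds shown leave open whether a 3-hydroxycyclopentyl group would fall with the six-membered or the four-membered hydroxy carbocycle. They also leave open whether an amine or a carboxylic acid in place of the hydroxy group on the cyclohexyl ring would keep the number of compound 1 at 48 nM.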